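Tetrahydropyridinyl to trifluoromethylpiperidinyl on the shared core

A few compounds are considered here, and "the series" means these few. Any claim that something is new, unique, unknown or untested is made for them only; others in the source may bear on it.

Measured values in a functional assay on CHO-K1 cells for antagonist activity at transient receptor potential cation channel subfamily V member 1 (Homo sapiens), read by FLIPR; a lower number here means a stronger inhibitor, a higher number a weaker inhibitor:
compound 1, `CC(C(=O)NCc1ccc(C(F)(F)F)nc1Nc1ccccc1)c1ccc(NS(C)(=O)=O)c(F)c1`: 1400 nM
compound 2, `CCCN(CCC)c1nc(C(F)(F)F)ccc1CNC(=O)C(C)c1ccc(NS(C)(=O)=O)c(F)c1`: 14.7 nM
compound 3, `CC(C(=O)NCc1ccc(C(F)(F)F)nc1N1CC=CCC1)c1ccc(NS(C)(=O)=O)c(F)c1`: 12.1 nM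

Compound 3 shows the lowest number of the three, but its nearest neighbour is compound 2, and the step of a 1.2-fold lower number from compound 2 to compound 3 (0.08 log units; within the scatter) lies within the scatter, so the two cannot be ordered. Compound 1 stands far apart: a 120-fold lower number from compound 1 to compound 3 (2.06 log units; beyond the scatter) and a 95-fold lower number from compound 1 to compound 2 (1.98 log units; beyond the scatter) are both large, and both replace the anilino group with a non-aromatic amine on the same aromatic carbon.

Compound 4, `CC(C(=O)NCc1ccc(C(F)(F)F)nc1N1CCC(C(F)(F)F)CC1)c1ccc(NS(C)(=O)=O)c(F)c1`, is not yet measured. It differs from compound 3 by a group of 10 heavy atoms (6 carbon, 1 nitrogen, 3 fluorine; one six-membered non-aromatic ring with 1 hetero atom) in place of a group of 6 heavy atoms (5 carbon, 1 nitrogen; one six-membered non-aromatic ring with 1 hetero atom), on an aromatic carbon, the group entering being 4-(trifluoromethyl)piperidin-1-yl, placed next to the ring nitrogen, ortho to a large group and meta to a trifluoromethyl group. The step that bears on this is a 1.2-fold lower number from compound 2 to compound 3 (0.08 log units; within the scatter): exchanging one non-aromatic amine for another, ring or chain, left the number within the scatter. Exchanging one six-membered non-aromatic ring for another is therefore expected to give a step of about a 1.2-fold higher number from compound 3 to compound 4 (0.09 log units; within the scatter), with no change beyond the scatter expected in this assay.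

For compound 4 the expected value is 15 nM, in the range 5 nM to 45 nM.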

Compound 4, half-maximal inhibitory concentration: 31 nM
Estimate against measurement, compound 4: 2.1-fold (0.32 log units) below; measured number inside the range.
By their numbers in this assay, from the lowest: compounds 3 and 2 (each within the scatter of the next); then compound 4; then compound 1.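

In this assay the non-aromatic amines on this aromatic carbon are no longer all interchangeable: a 2.6-fold higher number from compound 3 to compound 4 (0.41 log units; beyond the scatter) and a 2.1-fold higher number from compound 2 to compound 4 (0.32 log units; beyond the scatter) are modest but beyond the scatter, whereas compound 2 and compound 3 could not be ordered. Even so, 4-(trifluoromethyl)piperidin-1-yl keeps most of the distance from anilino, with a 45-fold lower number from compound 1 to compound 4 (1.65 log units; beyond the scatter) remaining large. No measurement here explains the rise in number on moving to this ring.

The step from the ring of compound 3 removes a double bond and adds a trifluoromethyl group at once, so the compounds shown cannot apportion it between the two; unsubstituted piperidin-1-yl would separate them. Also open, going by these compounds, is how a morpholine ring or a 4-methylpiperidin-1-yl group would read at this position.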